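Halogen swap on the aryl triazole: chloro to bromo

The source may report more compounds than this note shows. Statements on the series, on what has been measured and on what is new or still open speak of the compounds shown alone.

The series shares one core, a diaryl urea linked through an ether to a triazole that carries an aryl group. Compound 1 `N#Cc1ccc(-n2cc(COc3cccc(NC(=O)Nc4ccc(Cl)c(C(F)(F)F)c4)c3)nn2)cc1` bears a cyano on that aryl ring; in a functional assay on HepG2 cells (Homo sapiens) for inhibition, read by MTT assay, with a stated time of 72 h (a lower number here means a stronger inhibitor, a higher number a weaker inhibitor), compound 1 gives 2980 nM. Compound 2 `O=C(Nc1cccc(OCc2cn(-c3ccc(Cl)cc3)nn2)c1)Nc1ccc(Cl)c(C(F)(F)F)c1` carries a chloro in its place, and in this assay compound 2 gives 2490 nM. The step from one to the other is a 1.2-fold lower number from compound 1 to compound 2 (0.08 log units; within the scatter), so the two numbers lie within the scatter of each other, and compound 2 cannot be set apart from compound 1 on these measurements.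

Compound 3 `O=C(Nc1cccc(OCc2cn(-c3ccc(Br)cc3)nn2)c1)Nc1ccc(Cl)c(C(F)(F)F)c1` differs from compound 2 by a single exchange: bromo in place of chloro on an aromatic carbon. For the measured compounds named here, the only measured step that bears on this change is the exchange of one small group for another at the same position, a 1.2-fold lower number from compound 1 to compound 2 (0.08 log units; within the scatter), which stayed within the scatter. With nothing else to lean on, compound 3 is expected to show a step of a 1.0-fold lower number from compound 2 to compound 3 (0.02 log units; within the scatter) in this assay, no more than the scatter. Compound 3 is therefore estimated at 2400 nM, within 1200 nM to 4800 nM.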

Compound 3, half-maximal inhibitory concentration: 2730 nM
Beside the measured number, compound 3's estimate is 1.1-fold (0.06 log units) below it; the measured number falls inside the stated range.
By their numbers in this assay, from the lowest: compounds 2, 3 and 1 (each within the scatter of the next).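

The earlier pair had set only cyano against chloro on this aromatic carbon. In this assay the change from 4-chlorophenyl to 4-bromophenyl adds a second halogen to that comparison, and the swap gives a 1.1-fold higher number from compound 2 to compound 3 (0.04 log units; within the scatter) with one heavy atom exchanged for another, so moving between these two halogens does not separate the compounds. Read against the cyano group, bromo gives a 1.1-fold lower number from compound 1 to compound 3 (0.04 log units; within the scatter) and all three groups at this place, cyano, chloro and bromo, therefore remain indistinguishable on these measurements, while nothing available speaks to what lies behind this lack of separation.

The compounds shown leave open whether this position would stay as flat with a group of a different kind, such as an amine, a carboxylic acid or a methoxy group, or with no substituent there at all. They also leave open whether any change elsewhere on this ring, or in the rest of the shared core, would move the number beyond the scatter in this assay at all.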